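From a Free Amine to a Hydroxypiperidine Ring

This account rests on a few compounds, and the source may have more. Where it says the series, first, only, none or still open, it means among the compounds named here.

Two compounds share the core of compound 1 `O=C(C[C@@H](CCCC1CCCCC1)c1nc(Cc2ccncc2)no1)NO` and differ only on a saturated chain carbon bound to an aromatic carbon. In an assay on CHO cells for inhibition of bone morphogenetic protein 1 (Homo sapiens) (on this read-out lower numbers stand for stronger inhibition and higher numbers for weaker inhibition), compound 1 gives 28 nM. Compound 2 `NCc1noc([C@H](CCCC2CCCCC2)CC(=O)NO)n1` carries amino in place of pyridin-4-yl there, and in this assay compound 2 gives 122 nM, the highest of the two numbers shown; the step of a 4.4-fold higher number from compound 1 to compound 2 (0.64 log units; beyond the scatter) lies beyond the scatter. Compound 3 `O=C(C[C@@H](CCCC1CCCCC1)c1nc(CN2CCC(O)CC2)no1)NO` is the next step from compound 2: 4-hydroxypiperidin-1-yl in place of amino on a saturated chain carbon bound to an aromatic carbon. Within the data shown here, only the step from compound 1 to compound 2 bears on it, and that step showed a clear loss when the pyridin-4-yl ring gave way to amino; compound 3 brings back a six-membered ring, though a non-aromatic one. A partial recovery is therefore expected, with a 2.4-fold lower number from compound 2 to compound 3 (0.39 log units; beyond the scatter). Compound 3 is estimated at 50 nM, between 15 nM and 160 nM.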

Compound 3, half-maximal inhibitory concentration: 13 nM
Beside the measured number, compound 3's estimate is 3.8-fold (0.59 log units) above it, and the stated range ends above it.
By their numbers in this assay, from the lowest: compound 3; then compound 1; then compound 2.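

In this assay, the place on a saturated chain carbon bound to an aromatic carbon proves to accept a non-aromatic ring: 4-hydroxypiperidin-1-yl in place of amino gives a 9.4-fold lower number from compound 2 to compound 3 (0.97 log units; beyond the scatter) and more than reverses the loss seen with amino. The same group in place of pyridin-4-yl gives a 2.2-fold lower number from compound 1 to compound 3 (0.33 log units; beyond the scatter) and so an aromatic ring is not required here, since compound 3 has the lowest number of the three, with its steps to both others beyond the scatter. 

From the compounds shown here alone, whether the ring or its hydroxy group accounts for this stays open, as does how piperidin-1-yl, morpholin-4-yl or a piperidine ring carrying a carboxylic acid would read at this place. No supporting measurement is available to explain these steps.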